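Steroidal isoxazoline esters: an aryl swap on the oxime ring

The compounds below may be only part of what the source reports. "The series", "measured", "known", "first", "only" and "open" are said of these compounds alone.

Measured so far:
- compound 1, `COc1ccc(C2=NO[C@]3(C2)C(=O)O[C@@H]2[C@H]3CC[C@H](C)[C@]3(O)C=CC(=O)[C@@]23C)cc1`: 20000 nM
- compound 2, `C[C@H]1CC[C@@H]2[C@@H](OC(=O)[C@]23CC(c2ccc(Cl)cc2)=NO3)[C@]2(C)C(=O)C=C[C@@]12O`: 43000 nM
- compound 3, `C[C@H]1CC[C@@H]2[C@@H](OC(=O)[C@]23CC(c2ccc(N(C)C)cc2)=NO3)[C@]2(C)C(=O)C=C[C@@]12O`: 4500 nM

In a functional assay on DU-145 cells (Homo sapiens) for cytotoxicity, read by sulforhodamine B assay, with a stated time of 48 h (on this read-out lower numbers stand for stronger inhibition and higher numbers for weaker inhibition), compound 2 gives the highest number of the three, with compound 1 nearest and compound 3 furthest. The two measured steps that touch compound 2 point in opposite directions: a 2.2-fold higher number from compound 1 to compound 2 (0.33 log units; beyond the scatter), while a 9.6-fold lower number from compound 2 to compound 3 (0.98 log units; beyond the scatter). A third step, a 4.4-fold lower number from compound 1 to compound 3 (0.65 log units; beyond the scatter), shows that the gap between the methoxy and the dimethylamino is itself beyond the scatter.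

Compound 4, `COc1ccc(C2=NO[C@]3(C2)C(=O)O[C@@H]2[C@H]3CC[C@H](C)[C@]3(O)C=CC(=O)[C@@]23C)cc1OC`, is the unmeasured member. Against compound 2 the change is 3,4-dimethoxyphenyl in place of 4-chlorophenyl on a carbon with a double bond to nitrogen. Compound 4 thus restores the methoxy that compound 1 carries and adds a second one. As far as these compounds go, the step from compound 2 to compound 1 shows that the methoxy already gives a lower number than the chloro; the data hold no case of a second methoxy on this aryl ring, so its effect is unknown. Compound 4 is therefore expected to fall near or somewhat below compound 1, a step of roughly a 2.9-fold lower number from compound 2 to compound 4 (0.46 log units; beyond the scatter), and its estimated value in this assay is 15000 nM, with a plausible range from 5000 nM to 40000 nM.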

Compound 4, half-maximal inhibitory concentration: 84000 nM
Estimate against measurement, compound 4: 5.6-fold (0.75 log units) below; the whole stated range lies below it.
By their numbers in this assay, from the lowest: compound 3; then compound 1; then compounds 2 and 4 (each within the scatter of the next).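

In this assay, adding a methoxy to the aryl ring of compound 1 does not carry its advantage over compound 2 further, but reverses it, with a 4.2-fold higher number from compound 1 to compound 4 (0.62 log units; beyond the scatter), so at this position a second methoxy on the ring counts against the first. The 3,4-dimethoxyphenyl group and the 4-chlorophenyl group cannot be told apart here, at a 2.0-fold higher number from compound 2 to compound 4 (0.29 log units; within the scatter), while the 4-(dimethylamino)phenyl group remains clearly separate, with a 19-fold higher number from compound 3 to compound 4 (1.27 log units; beyond the scatter), and compound 3 keeps the lowest number of the four on steps that all lie beyond the scatter. Nothing at hand speaks to what lies behind these differences.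

As far as these compounds go, whether the higher number of compound 4 belongs to the added methoxy as such, or would also come with a hydroxyl or a methyl in its place on the ring, stays open. From the compounds shown here alone, it is also open whether the low number of compound 3 is particular to dimethylamino or would be shared by another amine on the aryl ring, such as a pyrrolidine or a morpholine.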